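Exchanging the Benzyl Ether's Ring Substituents on a Shared Core

The source may hold more compounds than are shown below. What is called first, only, known or untested is meant among the compounds shown, and "the series" means these compounds.

Of the compounds shown here, three built on one shared core have been measured in an assay on CHO cells for binding affinity to metabotropic glutamate receptor 2 (Rattus norvegicus); a higher number here means a weaker inhibitor, a lower number a stronger inhibitor. Compound 1 `CCC(C)O[C@@H]1C[C@@H]2[C@H]([C@]1(N)C(=O)O)[C@@]2(F)C(=O)O` gives 6.68 nM. Compound 2 `N[C@]1(C(=O)O)[C@H]2[C@@H](C[C@H]1OCc1ccccc1Cl)[C@]2(F)C(=O)O` gives 4.99 nM, and compound 3 `N[C@]1(C(=O)O)[C@H]2[C@@H](C[C@H]1OCc1ccccc1-c1ccccc1)[C@]2(F)C(=O)O` gives 4.07 nM. Compound 2 stands second highest of the three numbers; its nearest neighbour is compound 3 and its furthest is compound 1, and both gaps lie within the scatter. Among the measured compounds shown here, the only single-point step among them, a 1.2-fold lower number from compound 2 to compound 3 (0.09 log units; within the scatter), puts phenyl in place of chloro on an aromatic carbon and moves the number no further than the scatter.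

Compound 4 `N[C@]1(C(=O)O)[C@H]2[C@@H](C[C@H]1OCc1ccc(F)c(F)c1)[C@]2(F)C(=O)O` is not yet measured. It differs from compound 2 by 3,4-difluorophenyl in place of 2-chlorophenyl on a saturated chain carbon bound to an oxygen on a saturated carbon. For the measured compounds named here, no measured step exchanges one substituted phenyl for another, so only the step from compound 2 to compound 3 bears on it, and that step stayed within the scatter. For compound 4 a step no larger than the scatter, in no particular direction, is therefore expected, a 1.2-fold higher number from compound 2 to compound 4 (0.08 log units; within the scatter). Compound 4 is estimated at 6 nM, within a range from 2.5 nM to 15 nM.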

Compound 4, inhibition constant: 2.27 nM
Compound 4: middle estimate off by 2.6-fold (0.42 log units), on the high side; the measured number lies below the stated range.
By their numbers in this assay, from the lowest: compounds 4, 3, 2 and 1 (each within the scatter of the next, the first and the last beyond it).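

In this assay, among the compounds shown here, 3,4-difluorophenyl in place of 2-chlorophenyl on a saturated chain carbon bound to an oxygen on a saturated carbon gives a 2.2-fold lower number from compound 2 to compound 4 (0.34 log units; beyond the scatter), a modest step, but the first single-point step here to lie beyond the scatter. The earlier step, a 1.2-fold lower number from compound 2 to compound 3 (0.09 log units; within the scatter), changed only a substituent on the aromatic ring and stayed within the scatter, whereas this exchange shows that the number at this position can move when the ring's substituents are exchanged together. Nothing available explains the step, and the data cannot separate the departure of the chlorine from the arrival of the two fluorines.

The compounds shown leave open whether a single fluorine on the ring would give the same step. They also leave open how an amine or a carboxylic acid on the ring, or a longer chain in place of the benzyl group, would read in this assay here.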